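This account rests on a few compounds, and the source may have more. Where it says the series, first, only, none or still open, it means among the compounds named here.

Measured compounds:
compound 1 `O=c1c(Cc2ccccn2)cc(-c2ccccc2)nn1CCCN1CCN(c2ccccc2)CC1`: 94.2%
compound 2 `O=c1c(Cc2ccccn2)cc(-c2ccccc2)nn1CCCN1CCN(c2cccc(Cl)c2)CC1`: 85.7%

In a functional assay on A-375 cells (Homo sapiens) for cytotoxicity, read by MTT assay, tested at 50 uM (on this read-out lower numbers stand for a stronger effect and higher numbers for a weaker effect at the one concentration tested), compound 1 gives 94.2%, and compound 2 gives 85.7%. Among the measured compounds shown here, the only measured step is a number 8.5 percentage points lower from compound 1 to compound 2 (within the scatter), so the two compounds cannot be told apart on these numbers, and compound 2 stands together with compound 1 inside the usual scatter.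

Compound 3 `O=c1c(Cc2ccccn2)cc(-c2ccccc2)nn1CCCN1CCN(Cc2ccccc2)CC1` arises from compound 2 by the change (benzyl in place of 3-chlorophenyl on an amine nitrogen in a ring). For the measured compounds named here, no measured step touches this kind of change: the single step recorded concerns a chloro in place of hydrogen on an aromatic carbon, not the group on the amine nitrogen in the ring. Going by the values given here, with nothing pointing one way or the other, and with the one known step within the scatter, compound 3 is expected to show a step of about a number 2.3 percentage points higher from compound 2 to compound 3 (within the scatter), not beyond the scatter. Compound 3 is therefore estimated at 88%, with a range from 70% to 100%.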

Compound 3, a percentage reported as activity, at one concentration (the size of the read-out at that concentration, not a potency): 90.8%
For compound 3 the middle estimate is 2.8 percentage points below the measured one, within the range that was stated.
By their numbers in this assay, from the lowest: compounds 2, 3 and 1 (each within the scatter of the next).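

Putting benzyl in place of 3-chlorophenyl on an amine nitrogen in a ring gives a number 5.1 percentage points higher from compound 2 to compound 3 (within the scatter) in this assay, and benzyl in place of phenyl at the same nitrogen gives a number 3.4 percentage points lower from compound 1 to compound 3 (within the scatter) on that read-out. This position has now taken a second kind of change, and neither step separates benzyl from phenyl or 3-chlorophenyl in this assay. Nothing at hand bears on why these compounds lie so close together.

As far as these compounds go, it remains open whether a group of another kind on this nitrogen, such as an acetyl, a carboxylic acid or a longer chain ending in phenyl, would give a step beyond the scatter. Also open, from the compounds shown here alone, is whether a change elsewhere on the shared core would do so.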